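The compounds below may be only part of what the source reports. "The series", "measured", "known", "first", "only" and "open" are said of these compounds alone.

Compound 2, with the structure `Nc1nc(NC2CC2)c2ncn(/C=C3/CC3(CO)CO)c2n1`, was examined in an ADME assay on Akata cells (Homo sapiens) for cytotoxicity, with a stated time of 7 days; a higher number here means that more compound is tolerated, a lower number that less compound is tolerated. In this assay compound 2 gives only a limit, > 20000 nM. Compound 1, with the structure `CN(C)c1nc(N)nc2c1ncn2/C=C1/CC1(CO)CO`, also gives only a limit in this assay, namely > 24000 nM. The step that the two limits leave unreadable from compound 1 to compound 2 cannot be read because the limit of > 20000 nM in this assay, at which 1 of the 2 values shown sits, and the limit of > 24000 nM in this assay, at which 1 of the 2 values shown sits, show both ends of it sitting at the edge of what the assay reports. Compound 3 has the structure `CC(C)Sc1nc(N)nc2c1ncn2/C=C1/CC1(CO)CO`. It differs from compound 2 by isopropylsulfanyl in place of cyclopropylamino on an aromatic carbon. Among the compounds with values here, no measured step with a readable size bears on this change, so nothing in the data points to a move in either direction beyond the scatter, and the most likely outcome for compound 3 is once more a value at or past the reporting limit. The step that the limit leaves unreadable from compound 2 to compound 3 is therefore expected to be essentially flat. Compound 3 is estimated at 24000 nM, within 12000 nM to 50000 nM.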

Compound 3, half-maximal cytotoxic concentration: > 20000 nM
Compound 3 gave a limit, no number (the forecaster's own chance of this, stated with the estimate: 80%); the middle value does not contradict the limit.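

Compound 3, like compound 1 and compound 2, gives only a limit and not a number, so no step among these compounds can be read: the limit of > 20000 nM in this assay, at which 2 of the 3 values shown sit. The compounds shown leave open where each true value lies in this assay, and whether changing the group on the aromatic carbon alters it at all.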